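This account rests on a few compounds, and the source may have more. Where it says the series, first, only, none or still open, it means among the compounds named here.

Two compounds of this series have been measured in a functional assay on MV cells (Homo sapiens) for inhibition, read by sulforhodamine B assay; a higher number here means a weaker inhibitor, a lower number a stronger inhibitor:
compound 1, `C#CC(=O)N1C(C(C)CCC)SC[C@@H]1C(=O)OCC`, gives 500 nM;
compound 2, `C#CC(=O)N1C(c2ccccc2F)SC[C@@H]1C(=O)OCC`, gives 1700 nM.

Within this pair compound 2 stands at the higher of the two numbers, and the sole measured step, a 3.4-fold higher number from compound 1 to compound 2 (0.53 log units; beyond the scatter), separates it from compound 1. Compound 3, `C#CC(=O)N1C(CCCCC)SC[C@@H]1C(=O)OCC`, has not yet been measured. The change that leads to it is pentyl in place of 2-fluorophenyl on a saturated ring carbon. For the measured compounds named here, only one measured step bears on this change, and it runs the opposite way: a 3.4-fold higher number from compound 1 to compound 2 (0.53 log units; beyond the scatter) placed the 2-fluorophenyl group on the same saturated ring carbon in place of 1-methylbutyl. Compound 3 instead carries a pentyl chain at that position, which resembles the 1-methylbutyl group of compound 1 more closely than the 2-fluorophenyl group of compound 2. The step is therefore expected to roughly undo the earlier rise, so a lower number than compound 2 is expected in this assay, about a 2.8-fold lower number from compound 2 to compound 3 (0.45 log units; beyond the scatter). Compound 3 is estimated at 600 nM, with a likely range from 250 nM to 1500 nM.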

Compound 3, half-maximal inhibitory concentration: 2000 nM
Compound 3: the middle estimate sits 3.3-fold (0.52 log units) below what was measured; the measured number lies above the stated range.
By their numbers in this assay, from the lowest: compound 1; then compounds 2 and 3 (each within the scatter of the next).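

In this assay, exchanging the 2-fluorophenyl ring for an open pentyl chain on this saturated ring carbon gives a 1.2-fold higher number from compound 2 to compound 3 (0.07 log units; within the scatter), so among these compounds an aromatic ring and an open chain at this position cannot be told apart. The difference lies instead between the two open chains: replacing the branched 1-methylbutyl with unbranched pentyl gives a 4.0-fold higher number from compound 1 to compound 3 (0.60 log units; beyond the scatter), a step beyond the scatter, so having an open chain here is not enough to match compound 1, and the branched 1-methylbutyl group alone stands apart from the other two. Nothing available explains why this branched chain differs from the unbranched one.

The three compounds leave open whether other branched groups, such as isopropyl or tert-butyl, would share the lower number of compound 1, or whether this is particular to 1-methylbutyl. From the compounds shown here alone, they also do not show what an unsubstituted phenyl, a cyclohexyl ring or a shorter or longer unbranched chain would give at this position, so the fluorine of compound 2 and the length of the pentyl chain of compound 3 remain untested as separate features.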